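Compound 2 gains a methoxy: an expected clearance

The compounds below may be only part of what the source reports. "The series", "measured", "known", "first", "only" and "open" are said of these compounds alone.

Compound 1 `CCCN(CC1CCOCC1)c1c(CC)nn2c(-c3c(OC)cc(COC)cc3OC)cccc12` gives 700 mL.min-1.g-1
Compound 2 `CCc1nn2c(-c3c(OC)cc(C)cc3OC)cccc2c1N(CC1CCOCC1)CC1CC1` gives 440 mL.min-1.g-1

In an in vitro ADME assay on microsomes from liver (Homo sapiens) for metabolic stability, with a stated time of 15 min (a lower number here means slower removal, a higher number faster removal of the compound), compound 2 stands at 440 mL.min-1.g-1 and compound 1 at 700 mL.min-1.g-1 (two values within the usual scatter of each other). Compound 3 `CCc1nn2c(-c3c(OC)cc(COC)cc3OC)cccc2c1N(CC1CCOCC1)CC1CC1` has not yet been measured. It differs from compound 2 by methoxy in place of hydrogen on a saturated chain carbon bound to an aromatic carbon with methoxy in place of hydrogen on a saturated chain carbon bound to an aromatic carbon, which reads as methyl to methoxymethyl. Among the measured compounds shown here, no measured pair isolates this change, so only a small upward move, within the scatter, is expected. The expected step is a 1.3-fold higher number from compound 2 to compound 3 (0.10 log units; within the scatter) in size. For compound 3 the estimated value is 560 mL.min-1.g-1 (range 290 mL.min-1.g-1 to 1000 mL.min-1.g-1).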

Compound 3, intrinsic clearance in microsomes: 300 mL.min-1.g-1
For compound 3 the middle estimate is 1.9-fold (0.27 log units) above the measured one, and the stated range covers the measured number.
By their numbers in this assay, from the lowest: compounds 3, 2 and 1 (each within the scatter of the next, the first and the last beyond it).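

In this assay, methoxy in place of hydrogen on a saturated chain carbon bound to an aromatic carbon gives a 1.5-fold lower number from compound 2 to compound 3 (0.17 log units; within the scatter), so at this position the methyl to methoxymethyl change stays within the scatter. The other change, cyclopropyl in place of ethyl on a saturated chain carbon bound to a nitrogen on an aromatic ring, gives a 2.3-fold lower number from compound 1 to compound 3 (0.37 log units; beyond the scatter), a modest step and the only one here beyond the scatter. Nothing available explains either step. As far as these compounds go, whether an amine or a carboxylic acid at the methoxy position would stay within the scatter remains open. So does whether the cyclopropyl step holds in other compounds.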